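The source may report more compounds than this note shows. Statements on the series, on what has been measured and on what is new or still open speak of the compounds shown alone.

Measured in an ADME assay on Vero 76 cells (Chlorocebus sabaeus) for cytotoxicity, read by MTT assay, with a stated time of 96 h; on this read-out higher numbers stand for lower toxicity in this test and lower numbers for higher toxicity in this test:
- Compound 1 `Cc1ccccc1C1CC(c2ccc(OCc3ccccc3)cc2)=NN1c1ccc(S(N)(=O)=O)cc1`: 100000 nM
- Compound 2 `Cc1cccc(C2CC(c3ccccc3)=NN2c2ccc(S(N)(=O)=O)cc2)c1`: 25000 nM

Compound 2 has the lower of the two numbers, and its gap to compound 1 lies beyond the usual scatter of repeated measurements. Compound 3 `Cc1ccccc1C1CC(c2ccccc2)=NN1c1ccc(S(N)(=O)=O)cc1` has the same atoms as compound 2, joined differently, with 2-methylphenyl in place of 3-methylphenyl on a saturated ring carbon. For the measured compounds named here, no two measured compounds differ in just one place, so no measured step shows what a change like this does in this assay. The expectation therefore starts from compound 2 at 25000 nM. The expected 1.2-fold higher number from compound 2 to compound 3 (0.08 log units; within the scatter) is small and stays within the scatter. For compound 3 the estimated value is 30000 nM, with an expected range from 10000 nM to 100000 nM.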

Compound 3, half-maximal cytotoxic concentration: 24000 nM
The estimate for compound 3 lay 1.3-fold (0.10 log units) above the measured number, and the stated range covers the measured number.
By their numbers in this assay, from the lowest: compounds 3 and 2 (each within the scatter of the next); then compound 1.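

In this assay, 2-methylphenyl in place of 3-methylphenyl on a saturated ring carbon gives a 1.0-fold lower number from compound 2 to compound 3 (0.02 log units; within the scatter), so this shift of the methyl group leaves the two compounds indistinguishable in this test. Hydrogen in place of benzyloxy on an aromatic carbon gives a 4.2-fold lower number from compound 1 to compound 3 (0.62 log units; beyond the scatter), a modest step beyond the scatter, so this is the one change shown here that registers in this assay. Nothing available explains either result.

Still open, on these data alone, is whether an amine or a carboxylic acid in place of the methyl group on that phenyl ring would also leave the number where it is. Also open, as far as these compounds go, is whether a smaller ether such as methoxy, in place of benzyloxy, would give a number closer to that of compound 1 or compound 3.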